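A few compounds are considered here, and "the series" means these few. Any claim that something is new, unique, unknown or untested is made for them only; others in the source may bear on it.

Measured compounds:
compound 1, `COc1ccccc1OCc1cc(C)nc(-c2ccccn2)n1`, in a functional assay on cells for antagonist activity at Free fatty acid receptor 1 (Homo sapiens), read by TR-FRET and inositol phosphate accumulation, with a stated time of 2 h; a higher number here means a weaker inhibitor, a lower number a stronger inhibitor: 2000 nM
compound 2, `COc1cccc(OCc2cc(C)nc(-c3ccccn3)n2)c1`, in this assay: 2000 nM
compound 3, `Cc1cc(COc2ccccc2C#N)nc(-c2ccccn2)n1`, in this assay: 10000 nM

Compound 1 and compound 2 have the same atoms joined differently; the difference between the two cores is not broken down here. In this assay the two stand level at the digits read, within the scatter of each other, so no order is drawn between them.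

One change has a measured step. Going from compound 1 to compound 3 the change is cyano in place of methoxy on an aromatic carbon. In this assay it gives a 5.0-fold higher number from compound 1 to compound 3 (0.70 log units; beyond the scatter).

Compound 4, `Cc1cc(COc2cccc(C#N)c2)nc(-c2ccccn2)n1`, is not yet measured. It stands to compound 2 as compound 3 stands to compound 1: cyano in place of methoxy on an aromatic carbon. This is the same kind of change, not the same change: in compound 1 the place is ortho to a large group, in compound 2 it is meta to a large group.

The expectation for compound 4 rests on one step only. Because compound 1 to compound 3 gave a 5.0-fold higher number from compound 1 to compound 3 (0.70 log units; beyond the scatter), a step of similar size is expected in this assay, namely a 5.0-fold higher number from compound 2 to compound 4 (0.70 log units; beyond the scatter). Whether the meta placement carries the change as the ortho placement did is not known from these three compounds, so the range is left wide. Compound 4 is estimated at 10000 nM in this assay, with 3000 nM to 30000 nM as the expected span.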

Compound 4, half-maximal inhibitory concentration: 2510 nM
The estimate for compound 4 lay 4.0-fold (0.60 log units) above the measured number; measured number below the stated range.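

In this assay, cyano in place of methoxy on an aromatic carbon, here meta to a large group, gives a 1.3-fold higher number from compound 2 to compound 4 (0.10 log units; within the scatter), so on this core the change leaves the number within the scatter. The same kind of change therefore did not carry over at a fixed size from one core to the other, and the penalty seen on the core of compound 1 cannot be assumed for a related core in this series: the same change on two cores in this assay, a 5.0-fold higher number (0.70 log units; beyond the scatter) from compound 1 to compound 3 and a 1.3-fold higher number (0.10 log units; within the scatter) from compound 2 to compound 4, 4.0-fold (0.60 log units) apart, beyond the scatter of two such steps These two pairs show that the size of the step depends on its setting, but they do not show what sets it, since the two cores differ in how the same atoms are joined, and two pairs give no rule for predicting the step on a third core.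

The compounds shown leave open how other groups in the same place would behave on either core, for example an amine, a carboxylic acid or a longer chain such as ethoxy in place of methoxy. They also leave open whether replacing the methyl group on the shared core would change the size of the cyano step on either core.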